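Working notes: amine change on a thiocarbonyl carbon

The compounds below may be only part of what the source reports. "The series", "measured", "known", "first", "only" and "open" are said of these compounds alone.

Of the compounds shown here, two have been measured in a toxicity assay on HeLa cells (Homo sapiens) for cytotoxicity, read by MTT assay, with a stated time of 24 h; a higher number here means a weaker inhibitor, a lower number a stronger inhibitor. Compound 1 `CCOC(=O)N1CCN(C(=S)SCC(O)Cn2c([N+](=O)[O-])cnc2C)CC1` gives 1610000 nM in this assay. Compound 2 `Cc1ncc([N+](=O)[O-])n1CC(O)CSC(=S)N1CCCC1` gives 1340000 nM in this assay. Going by the values given here, the two numbers sit within the usual scatter of each other, so no ranking between compound 1 and compound 2 follows from this assay, and no step between them is on record.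

Compound 3 `Cc1ncc([N+](=O)[O-])n1CC(O)CSC(=S)N1CCCC(C)C1` is not yet measured. It differs from compound 2 by 3-methylpiperidin-1-yl in place of pyrrolidin-1-yl on a thiocarbonyl carbon. No comparable change among the measured compounds is available to set its size. Both measured numbers sit close together, which gives no sign that a change on this amine moves this assay, so the step from compound 2 to compound 3 is expected to stay within the scatter, with no clear direction. The estimate for compound 3 in this assay is 1300000 nM, with a range from 500000 nM to 3500000 nM, which corresponds to an expected step of a 1.0-fold lower number from compound 2 to compound 3 (0.01 log units; within the scatter).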

Compound 3, half-maximal inhibitory concentration: 609000 nM
Compound 3: middle estimate off by 2.1-fold (0.33 log units), on the high side, and the stated range covers the measured number.
By their numbers in this assay, from the lowest: compound 3; then compounds 2 and 1 (each within the scatter of the next).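

In this assay the amine on a thiocarbonyl carbon turns out to be a place where a change can register: 3-methylpiperidin-1-yl in place of pyrrolidin-1-yl gives a 2.2-fold lower number from compound 2 to compound 3 (0.34 log units; beyond the scatter) and this modest step points toward a lower number. Compound 1 and compound 2 sit within the scatter of each other, so they gave no sign that this amine could shift the read-out. Nothing on record bears on what lies behind this step.

The change swaps the ring size and adds the methyl group together, so the two contributions stay unseparated, and piperidin-1-yl itself would tell them apart. Also open, on these data alone, is how morpholin-4-yl or a dimethylamino group on the same thiocarbonyl carbon would read in this assay and whether numbers lower still can be reached at this place.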